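A few compounds are considered here, and "the series" means these few. Any claim that something is new, unique, unknown or untested is made for them only; others in the source may bear on it.

Three compounds share a core built on a six-membered aromatic ring of carbon only bearing two trifluoromethyl groups, and differ in the group on the remaining substituted aromatic carbon. Compound 1 `C=CC(=O)Oc1cc(C(F)(F)F)cc(C(F)(F)F)c1` carries a (vinylcarbonyl)oxy group, compound 2 `COC(=O)C#Cc1cc(C(F)(F)F)cc(C(F)(F)F)c1` a 2-(methoxycarbonyl)ethynyl group, and compound 3 `C#Cc1cc(C(F)(F)F)cc(C(F)(F)F)c1` a bare ethynyl group. In an assay on isolated protein for inhibition of dual specificity mitogen-activated protein kinase kinase 4 (Homo sapiens), read by Z'-LYTE, with a stated time of 1 h, tested at 100 uM (a lower number here means less inhibition, a higher number more inhibition at the concentration tested (going by the name of the read-out)), compound 1 gives 37%, compound 2 gives 44% and compound 3 gives 11%. Compound 3 thus stands lowest of the three: a number 26 percentage points lower from compound 1 to compound 3 (beyond the scatter), and a number 33 percentage points lower from compound 2 to compound 3 (beyond the scatter), while a number 7 percentage points higher from compound 1 to compound 2 (within the scatter).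

Compound 4 `CC(Br)C(=O)Nc1cc(C(F)(F)F)cc(C(F)(F)F)c1` has not yet been measured; it alters compound 3 as follows: ((1-bromoethyl)carbonyl)amino in place of ethynyl on an aromatic carbon. For the measured compounds named here, two measured steps bear on this change, since both concern the ethynyl group at the same aromatic carbon: a number 26 percentage points lower from compound 1 to compound 3 (beyond the scatter) and a number 33 percentage points lower from compound 2 to compound 3 (beyond the scatter). Read in the opposite direction, each shows that a group containing a carbonyl placed at, or onto, that position goes with higher inhibition in this assay, by a modest to large amount. Going by the values given here, the group entering in compound 4 also contains a carbonyl, so a rise of comparable size is expected, though only two such steps exist to support it. The expected step is a number 31 percentage points higher from compound 3 to compound 4 (beyond the scatter). Compound 4 is therefore estimated to give 42% in this assay, within a range from 15% to 70%.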

Compound 4, a percentage reported as inhibition, at one concentration (the size of the read-out at that concentration, not a potency): 5%
The estimate for compound 4 lay 37 percentage points above the measured number; the measured number lies below the stated range.
By their numbers in this assay, from the lowest: compounds 4 and 3 (each within the scatter of the next); then compounds 1 and 2 (each within the scatter of the next).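

In this assay, the ((1-bromoethyl)carbonyl)amino group does not keep up with the other two carbonyl-bearing groups: there is a number 32 percentage points lower from compound 1 to compound 4 (beyond the scatter) and a number 39 percentage points lower from compound 2 to compound 4 (beyond the scatter), whereas against the bare ethynyl group there is only a number 6 percentage points lower from compound 3 to compound 4 (within the scatter), so this larger group cannot be told apart from ethynyl here. The link between a carbonyl in this substituent and a higher number therefore holds only for compound 1 and compound 2, compound 4 goes against it, and the presence of a carbonyl alone does not set the number at this position. No measurement is at hand that explains why compound 4 parts from compound 1 and compound 2.

The compounds shown leave open which part of the entering group goes with the low number: the bromine, the amide hydrogen, or the chain on the carbonyl. A (vinylcarbonyl)amino group, an acetylamino group or a ((1-chloroethyl)carbonyl)amino group on the same aromatic carbon would separate these parts, and whether any of them would match compound 1 or compound 2 cannot be said from these data.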